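Lipophilicity of a thioester analogue of a dienoate chain

A few compounds are considered here, and "the series" means these few. Any claim that something is new, unique, unknown or untested is made for them only; others in the source may bear on it.

The measured compounds and their values:
compound 1 `COC(=O)/C=C(C)/C=C/CC(C)CCCC(C)C`, 6.2
compound 2 `COC(=O)/C=C(C)/C=C/CC(C)CCCC(C)(C)OC`, 5
compound 3 `CC(/C=C/CC(C)CCCC(C)(C)OC(C)C)=C\C(=O)OC(C)C`, 6.9

In a physicochemical assay for lipophilicity (on this read-out higher numbers stand for higher lipophilicity and lower numbers for lower lipophilicity), compound 1 stands second highest of the three. Compound 3 lies above it by a gap beyond the scatter, and compound 2 lies below it: the step of a number 1.20 log units lower from compound 1 to compound 2 (beyond the scatter), a large one. The unmeasured compound 4 `CC(/C=C/CC(C)CCCC(C)C)=C\C(=O)SC(C)C` differs from compound 1 at the carbonyl carbon: isopropylsulfanyl in place of methoxy on a carbonyl carbon. Among the compounds with values here, no measured step touches the carbonyl carbon; the only step, from compound 1 to compound 2, concerns a saturated chain carbon. The values of compound 1 and compound 3 show that replacing methyl and hydrogen by two isopropyl groups raises the number, but those two changes cannot be separated. Since the isopropylsulfanyl that enters counts more heavy atoms than the methoxy that leaves, an upward step is expected: a number 1.30 log units higher from compound 1 to compound 4 (beyond the scatter). Compound 4 is therefore estimated at 7.5, within 6.9 to 8.1.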

Compound 4, partition coefficient: 8.39
Compound 4: the middle estimate sits 0.89 log units below what was measured, and the stated range ends below it.
By their numbers in this assay, from the lowest: compound 2; then compound 1; then compound 3; then compound 4.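

In this assay, the carbonyl carbon proves to be a place where a single change moves the number strongly: isopropylsulfanyl in place of methoxy gives a number 2.19 log units higher from compound 1 to compound 4 (beyond the scatter), a large step. Within the data shown here, the only other single change available, methoxy in place of hydrogen on a saturated chain carbon, runs the opposite way, with a number 1.20 log units lower from compound 1 to compound 2 (beyond the scatter), so the two positions of compound 1 can be moved in either direction along this read-out. Nothing given here offers an explanation for the size of the new step.

The step swaps oxygen for sulfur and also enlarges the group, and the compounds shown leave open how much of it belongs to each. Methylsulfanyl on the same carbonyl carbon of the core of compound 1 would separate the two.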